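The source may report more compounds than this note shows. Statements on the series, on what has been measured and on what is new or still open speak of the compounds shown alone.

Measured in a functional assay on HeLa cells (Homo sapiens) for cytotoxicity, read by MTT assay; on this read-out higher numbers stand for weaker inhibition and lower numbers for stronger inhibition:
- Compound 1 `CCCC(O)CC(=O)O[C@H](CC=C(C)C)C1=CC(=O)c2c(O)ccc(O)c2C1=O`: 59300 nM
- Compound 2 `CC(C)=CC[C@@H](OC[C@@H](C)O)C1=CC(=O)c2c(O)ccc(O)c2C1=O`: 22500 nM

Compound 2 holds the lower of the two numbers. Compound 3 `CC(=O)OCCO[C@H](CC=C(C)C)C1=CC(=O)c2c(O)ccc(O)c2C1=O`, not yet measured, differs from it as follows: acetoxymethyl in place of 1-hydroxyethyl on a saturated chain carbon bound to an oxygen on a saturated carbon. The change is acetoxymethyl in place of 1-hydroxyethyl on a saturated chain carbon bound to an oxygen on a saturated carbon. Going by the values given here, only one measured step bears on this chain, the modest 2.6-fold lower number from compound 1 to compound 2 (0.42 log units; beyond the scatter). Compound 3, like compound 1, has a carbonyl in that chain, so a small upward step is expected, possibly within the scatter. The expected step is a 1.6-fold higher number from compound 2 to compound 3 (0.19 log units; within the scatter). Compound 3 is estimated at 35000 nM, with an expected range of 12000 nM to 90000 nM.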

Compound 3, half-maximal inhibitory concentration: 41500 nM
Estimate against measurement, compound 3: 1.2-fold (0.07 log units) below; the range from low to high includes it.
By their numbers in this assay, from the lowest: compounds 2, 3 and 1 (each within the scatter of the next, the first and the last beyond it).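

In this assay, acetoxymethyl in place of 1-hydroxyethyl on this saturated chain carbon gives a 1.8-fold higher number from compound 2 to compound 3 (0.27 log units; within the scatter) and so removes the hydrogen-bond donor and the defined stereocentre of that group without a step beyond the scatter. Likewise, 2-acetoxyethyl in place of (2-hydroxypentyl)carbonyl on an oxygen on a saturated carbon gives a 1.4-fold lower number from compound 1 to compound 3 (0.16 log units; within the scatter) in this read-out. Nothing measured here explains these numbers. The compounds shown leave open whether an amine or a carboxylic acid at this chain end would give a step beyond the scatter. They also leave open what a longer chain ending in a free hydroxyl would do.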